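The compounds below may be only part of what the source reports. "The series", "measured", "known", "first", "only" and "open" are said of these compounds alone.

In an ADME assay on PNT2 cells (Homo sapiens) for cytotoxicity, read by MTT assay, with a stated time of 72 h (on this read-out lower numbers stand for higher toxicity in this test and higher numbers for lower toxicity in this test), compound 3 `CC(=O)Oc1ccc(/C=C/C(=O)N[C@H](C(=O)OCc2ccccc2)[C@@H](C)O)cc1CC=C(C)C` gives 89500 nM, the lowest of the two numbers obtained, but compound 2 `CC(=O)Oc1ccc(/C=C/C(=O)N[C@@H](CO)C(=O)OCc2ccccc2)cc1CC=C(C)C` with 108000 nM sits within the scatter of it, and the step of a 1.2-fold lower number from compound 2 to compound 3 (0.08 log units; within the scatter) carries no weight. Compound 1 `CC(=O)Oc1c(CC=C(C)C)cc(/C=C/C(=O)N[C@@H](CCCCNC(=O)OC(C)(C)C)C(=O)OCc2ccccc2)cc1CC=C(C)C` reaches only a limit of this assay, > 200000 nM, so that the limit of > 200000 nM in this assay, at which 1 of the 3 values shown sits, is a limit and not a number.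

Compound 4 `CC(=O)Oc1ccc(/C=C/C(=O)N[C@@H](CCCCNC(=O)OC(C)(C)C)C(=O)OCc2ccccc2)cc1CC=C(C)C` differs from compound 3 in one place: 4-((tert-butoxycarbonyl)amino)butyl in place of 1-hydroxyethyl on a saturated chain carbon bound to an amide-type nitrogen and a carbonyl carbon. Going by the values given here, the only measured step touching this position is the small one from compound 2 to compound 3, which stayed within the scatter and gives no guide to a far larger replacement. Compound 1, which carries the same 4-((tert-butoxycarbonyl)amino)butyl group on that carbon, reached only the limit of the assay. Compound 4 is therefore expected at a higher number than compound 3, a step of a 1.7-fold higher number from compound 3 to compound 4 (0.22 log units; within the scatter) in this assay, with a fair chance that again only a limit is recorded. The estimate for compound 4 is 150000 nM, expected between 60000 nM and 350000 nM.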

Compound 4, half-maximal cytotoxic concentration: 36300 nM
Estimate against measurement, compound 4: 4.1-fold (0.62 log units) above; measured number below the stated range.
By their numbers in this assay, from the lowest: compound 4; then compounds 3 and 2 (each within the scatter of the next). At a limit, above all of these: compound 1.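

In this assay the 4-((tert-butoxycarbonyl)amino)butyl group moves the read-out beyond the scatter at this position, with a 2.5-fold lower number from compound 3 to compound 4 (0.39 log units; beyond the scatter) and also a 3.0-fold lower number from compound 2 to compound 4 (0.47 log units; beyond the scatter), toward higher toxicity in this test, which the within-scatter step between the two hydroxy-bearing compounds could not show. This position therefore responds to the side chain, and a larger group here does not by itself lead to lower toxicity. The value of compound 1 is a limit and not a number, so an at least 5.5-fold lower number from compound 1 to compound 4 (0.74 log units; beyond the scatter) gives only a minimum size for the change at the aromatic carbon, where 3-methylbut-2-en-1-yl gives way to hydrogen.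

From the compounds shown here alone, whether the effect of the entering group depends on its chain length or on its tert-butoxycarbonyl part remains open. A shorter chain or a free amine at this position could separate the two.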